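Removing a methyl from the aryl ether in a urea series

A few compounds are considered here, and "the series" means these few. Any claim that something is new, unique, unknown or untested is made for them only; others in the source may bear on it.

Of the compounds shown here, two have been measured in a functional assay on Hs-578T cells (Homo sapiens) for inhibition, read by sulforhodamine B assay, with a stated time of 48 h; on this read-out higher numbers stand for weaker inhibition of growth and lower numbers for stronger inhibition of growth. Compound 1, `O=C(Nc1cccc(-n2cc(-c3ccncc3)c(-c3ccc(Cl)c(O)c3)n2)c1)Nc1cccc(C(F)(F)F)c1`, gives 3310 nM in this assay. Compound 2, `COc1cc(-c2nn(-c3cccc(NC(=O)Nc4ccc(Cl)c(Cl)c4)c3)cc2-c2ccncc2)ccc1Cl`, gives 1430 nM, the lower of the two numbers, and its gap to compound 1 lies beyond the usual scatter. Compound 3, `O=C(Nc1cccc(-n2cc(-c3ccncc3)c(-c3ccc(Cl)c(O)c3)n2)c1)Nc1ccc(Cl)c(Cl)c1`, differs from compound 2 by hydrogen in place of methyl on an oxygen on an aromatic ring. For the measured compounds named here, no measured pair shows this change alone, so its effect is unknown here. The step of a 1.4-fold higher number from compound 2 to compound 3 (0.15 log units; within the scatter) is estimated to be small, if any, within the scatter. Compound 3 is expected to give 2000 nM, with a range from 700 nM to 6000 nM.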

Compound 3, concentration for 50% growth inhibition: 785 nM
Estimate against measurement, compound 3: 2.5-fold (0.41 log units) above; the range from low to high includes it.
By their numbers in this assay, from the lowest: compounds 3 and 2 (each within the scatter of the next); then compound 1.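

In this assay the swap of methoxy for hydroxy gives a 1.8-fold lower number from compound 2 to compound 3 (0.26 log units; within the scatter) and so leaves the two compounds indistinguishable: this position accepts either group without a readable change. With hydroxy held fixed, 3,4-dichlorophenyl in place of 3-(trifluoromethyl)phenyl gives a 4.2-fold lower number from compound 1 to compound 3 (0.62 log units; beyond the scatter) and does pass beyond the scatter. Nothing available here explains either result.

On these data alone, whether a longer ether such as ethoxy, or an amine, would behave the same way at this position stays open. So does whether the methoxy-for-hydroxy result holds alongside 3-(trifluoromethyl)phenyl.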